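The compounds below may be only part of what the source reports. "The series", "measured", "known", "first", "only" and "open" are said of these compounds alone.

Measured so far:
compound 1, `COc1ccc(C2=NNC(c3c(Cl)cccc3Cl)C2)cc1`, 54%
compound 2, `COc1ccc(C2CC(c3ccc(OC)c(OC)c3)=NN2C(=O)CBr)c(OC)c1`, 53%
compound 3, `COc1ccc(C2=NN(C(=O)CO[N+](=O)[O-])C(c3c(Cl)cccc3Cl)C2)cc1`, 34%

All three numbers come from a functional assay on the whole organism (strain albino) for inhibition, with Rattus norvegicus as the target, read by paw edema, with stated times of 30 min and 1 h, at a dose of 100 mg/kg by the oral route; a lower number here means less inhibition, a higher number more inhibition at the dose given (going by the name of the read-out). Compound 2 stands second highest of the three; its nearest neighbour is compound 1, which reads a touch higher but within the scatter, so the two cannot be ordered. Its furthest is compound 3, which lies beyond the scatter lower.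

The unmeasured compound 4, `COc1ccc(C2CC(c3ccc(OC)c(OC)c3)=NN2C(=O)C(C)O[N+](=O)[O-])c(OC)c1`, arises from compound 2 by 1-(nitrooxy)ethyl in place of bromomethyl on a carbonyl carbon.

Among the measured compounds shown here, only one measured step bears on it. Going from compound 1 to compound 3, the ring nitrogen acquires a ((nitrooxy)methyl)carbonyl group and the read-out moves by a number 20 percentage points lower from compound 1 to compound 3 (beyond the scatter), a modest loss beyond the scatter. In compound 2 the carbonyl is already present, so the change to compound 4 brings in only the nitrooxy-bearing carbon chain while the bromomethyl departs. For the measured compounds named here, no measured pair isolates that swap. Taking the nitrooxy entry as the common element, a smaller drop than the step from compound 1 to compound 3 is expected, though a result within the scatter of compound 2 cannot be excluded.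

Compound 4 is therefore estimated at 43% in this assay, within 28% to 57%. The expected step is a number 10 percentage points lower from compound 2 to compound 4 (within the scatter).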

Compound 4, a percentage reported as inhibition, in the whole organism at one dose (the size of the read-out at that dose, not a potency): 44%
Estimate against measurement, compound 4: 1 percentage points below, within the range that was stated.
By their numbers in this assay, from the lowest: compounds 3, 4, 2 and 1 (each within the scatter of the next, the first and the last beyond it).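

In this assay the swap on the carbonyl carbon gives a number 9 percentage points lower from compound 2 to compound 4 (within the scatter), so at this place, with the amide-type nitrogen in a ring as the other neighbour, bromomethyl can give way to 1-(nitrooxy)ethyl without a change that can be told from the scatter, even though the entering group brings hydrogen-bond acceptors and the leaving group has none. The earlier step, a number 20 percentage points lower from compound 1 to compound 3 (beyond the scatter), lay beyond the scatter, but it placed a whole acyl group on a ring nitrogen that carried hydrogen, so it could not show how the read-out responds to a change on a carbonyl carbon already in place. Nothing available accounts for how the read-out behaves across this swap.

Still open, as far as these compounds go, is whether a longer chain carrying the nitrooxy group, or an amine or a carboxylic acid in its place, would leave the read-out equally undisturbed on this carbonyl. Also open, from the compounds shown here alone, are whether the methyl branch of 1-(nitrooxy)ethyl contributes separately from the nitrooxy group, and whether one carbonyl substituent reads alike on the core of compound 1 and the core of compound 2.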